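Lengthening the Alkoxy Chain on a Piperazinyl-Pyridine Anticonvulsant

This account rests on a few compounds, and the source may have more. Where it says the series, first, only, none or still open, it means among the compounds named here.

Measured compounds:
compound 1, `Oc1cccc(N2CCNCC2)n1`, > 300 mg/kg
compound 2, `CCOc1cccc(N2CCNCC2)n1`, 30 mg/kg

Compound 1 `Oc1cccc(N2CCNCC2)n1` carries a free hydroxyl on the shared core. In a functional assay on the whole organism with Mus musculus as the target, in the maximal electroshock model, with a stated time of 30 min (on this read-out higher numbers stand for an effect only at larger amounts of compound and lower numbers for an effect already at smaller amounts), compound 1 gives only a limit, > 300 mg/kg, not a number. Going by the values given here, compound 2 `CCOc1cccc(N2CCNCC2)n1`, with ethyl in place of hydrogen on an oxygen on an aromatic ring, gives 30 mg/kg in this assay, the only actual number among the two values shown; the step of an at least 10-fold lower number from compound 1 to compound 2 (1.00 log units; beyond the scatter) is beyond the scatter, and it is measured against (the limit of > 300 mg/kg in this assay, at which 1 of the 2 values shown sits).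

Compound 3 `CC(C)COc1cccc(N2CCNCC2)n1` is not yet measured. It differs from compound 2 by isopropyl in place of methyl on a saturated chain carbon bound to an oxygen on an aromatic ring. No measured step bears directly on this change: the single step shown, an at least 10-fold lower number from compound 1 to compound 2 (1.00 log units; beyond the scatter), concerns the introduction of the alkyl group, not its further growth from ethyl to isobutyl. Whether a longer, branched chain helps or hurts is therefore open, and only a small step is expected, within or near the scatter, with a 1.5-fold lower number from compound 2 to compound 3 (0.18 log units; within the scatter). For compound 3 the estimate is 20 mg/kg, ranging from 7 mg/kg to 100 mg/kg.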

Compound 3, minimum effective dose: 10 mg/kg
Beside the measured number, compound 3's estimate is 2.0-fold (0.30 log units) above it, and the stated range covers the measured number.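

In this assay this position keeps responding after the first alkyl group is in place: going from ethyl to isobutyl on the oxygen gives a 3.0-fold lower number from compound 2 to compound 3 (0.48 log units; beyond the scatter). The earlier pair showed only that replacing the hydrogen on the oxygen mattered, whereas this step shows that the size and shape of the alkyl group also count, even though the ether is already present. The step from the free hydroxyl, an at least 30-fold lower number from compound 1 to compound 3 (1.47 log units; beyond the scatter), is open-ended on one side, as its starting point is a limit and not a number: the limit of > 300 mg/kg in this assay, at which 1 of the 3 values shown sits.

The change from ethoxy to isobutoxy alters chain length and branching together, so the compounds shown cannot separate the two, and a straight propyl or butyl chain would be needed to tell them apart. They also leave open whether the lower numbers in this assay continue with a longer chain such as hexyl or end soon after isobutyl, and how a methoxy group or an amine at the same place on the shared core would read.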